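The source may report more compounds than this note shows. Statements on the series, on what has been measured and on what is new or still open speak of the compounds shown alone.

Measured in a functional assay on HCT-116 cells (Homo sapiens) for antiproliferative activity, read by MTT assay, with a stated time of 72 h; on this read-out lower numbers stand for stronger inhibition and higher numbers for weaker inhibition:
compound 1 `COc1ccc(OCCCON2C(N)=NC(N)=NC23CCOCC3)cc1`: 1500 nM
compound 2 `NC1=NC2(CCOCC2)N(OCCCOc2ccccc2Cl)C(N)=N1`: 70 nM
compound 3 `NC1=NC2(CCOCC2)N(OCCCOc2ccc(Cl)cc2Cl)C(N)=N1`: 880 nM
Not yet measured: compound 4 `NC1=NC2(CCOCC2)N(OCCCOc2cc(Cl)c(Cl)cc2Cl)C(N)=N1`

Compound 1 sits at the high-number end of this small set, a place it shares with one other compound. The nearest step is a 1.7-fold lower number from compound 1 to compound 3 (0.23 log units; within the scatter), and the furthest is a 21-fold lower number from compound 1 to compound 2 (1.33 log units; beyond the scatter).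

The step followed here is 2,4,5-trichlorophenyl in place of 4-methoxyphenyl on an oxygen on a saturated carbon. In words, it puts 2,4,5-trichlorophenyl in place of 4-methoxyphenyl on an oxygen on a saturated carbon.

Going by the values given here, two measured steps bear most directly on this change. By name, the entering group is closest to the 2,4-dichlorophenyl of compound 3, so the best guide is the small step of a 1.7-fold lower number from compound 1 to compound 3 (0.23 log units; within the scatter). The second is a 13-fold higher number from compound 2 to compound 3 (1.10 log units; beyond the scatter), a large step showing that one added chloro in place of hydrogen on an aromatic carbon can undo most of what compound 2 gained. Among the compounds with values here, no measured compound carries a 2,4,5-trichlorophenyl group, so the direction of any further change remains open.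

The expected size is a 1.9-fold lower number from compound 1 to compound 4 (0.27 log units; within the scatter), so no step beyond the scatter is expected. In this assay, compound 4 is estimated at 800 nM, with an expected range of 150 nM to 3000 nM.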

Compound 4, half-maximal inhibitory concentration: 2750 nM
Estimate against measurement, compound 4: 3.4-fold (0.54 log units) below; low and high end bracket the measured number.
By their numbers in this assay, from the lowest: compound 2; then compounds 3, 1 and 4 (each within the scatter of the next, the first and the last beyond it).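

In this assay a further chloro in place of hydrogen on the aromatic ring again goes with a higher number, as a 3.1-fold higher number from compound 3 to compound 4 (0.49 log units; beyond the scatter) adds a modest step in the same direction as the large 13-fold higher number from compound 2 to compound 3 (1.10 log units; beyond the scatter) and so extends the single rise seen earlier into a run of two among these three chlorinated compounds. The whole change from one chloro to three is a 39-fold higher number from compound 2 to compound 4 (1.59 log units; beyond the scatter) and this shows that the low number of the 2-chlorophenyl compound does not survive on the 2,4,5-trichlorophenyl group, while a 1.8-fold higher number from compound 1 to compound 4 (0.26 log units; within the scatter) stays within the scatter and so sets this heavily chlorinated group level with the 4-methoxyphenyl group. Nothing measured here beyond these cell numbers explains why the added chloro groups act in this way.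

On these data alone, it remains open whether any other single group on this ring, such as 4-chlorophenyl, 2-fluorophenyl or 2-methylphenyl, would hold a number close to that of compound 2 at 70 nM in this assay. A longer chain between the two oxygens, or an amine at the end of it, is also untested among the compounds shown, so how these steps carry over to such changes is unknown.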